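The source may report more compounds than this note shows. Statements on the series, on what has been measured and on what is new or still open speak of the compounds shown alone.

Compound 1 `COC(=O)C1=C(C)NC(C)=C(C(=O)OC)C1c1[nH]cnc1Cl`, compound 2 `CCCOC(=O)C1=C(C)NC(C)=C(C(=O)OCCC)C1c1[nH]cnc1Cl` and compound 3 `CCOC(=O)C1=C(C)NC(C)=C(C(=O)OC)C1c1[nH]cnc1Cl` share one core and differ only in their two ester chains. In an assay on isolated protein for inhibition of Voltage-dependent L-type calcium channel subunit alpha-1C (Cavia porcellus) (on this read-out lower numbers stand for stronger inhibition and higher numbers for weaker inhibition), compound 1 gives 1200 nM, compound 2 gives 63.1 nM and compound 3 gives 661 nM. Among these three numbers compound 3 stands second highest, close to compound 1 and far from compound 2. Among the measured compounds shown here, the one single step measured, a 1.8-fold lower number from compound 1 to compound 3 (0.26 log units; within the scatter), stayed within the usual scatter when a methyl was added to one ester chain. Compound 4 `CCCOC(=O)C1=C(C)NC(C)=C(C(=O)OC)C1c1[nH]cnc1Cl` carries a change of the same kind: methyl in place of hydrogen on a saturated chain carbon, two bonds along the chain from an oxygen next to a carbonyl group. That earlier step bears on this one, so only a modest drop, if any, is expected: a 2.1-fold lower number from compound 3 to compound 4 (0.32 log units; beyond the scatter). For compound 4 in this assay a value around 320 nM is expected, most likely between 120 nM and 850 nM.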

Compound 4, half-maximal inhibitory concentration: 437 nM
Beside the measured number, compound 4's estimate is 1.4-fold (0.14 log units) below it; measured number inside the range.
By their numbers in this assay, from the lowest: compound 2; then compounds 4, 3 and 1 (each within the scatter of the next, the first and the last beyond it).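

In this assay the move from ethyl to propyl on one ester chain gives a 1.5-fold lower number from compound 3 to compound 4 (0.18 log units; within the scatter) and so does not separate these two compounds. Going from methyl to propyl on that same chain gives a 2.7-fold lower number from compound 1 to compound 4 (0.44 log units; beyond the scatter) so two added carbons together pass the scatter, while a larger step appears on the other ester chain, where propyl gives way to methyl: a 6.9-fold higher number from compound 2 to compound 4 (0.84 log units; beyond the scatter). Nothing measured here explains these differences. Going by these compounds, whether a longer chain such as butyl, or a chain ending in an amine, would take either ester further stays open.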